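Removing the Methyl from a Thiosemicarbazone Pyridine

The source may report more compounds than this note shows. Statements on the series, on what has been measured and on what is new or still open speak of the compounds shown alone.

Compound 1, `N/C(=N\NC(=S)N1CCCCCC1)c1ccccn1`: 2600 nM in a functional assay on MCF7 cells (Homo sapiens) for cytotoxicity, read by MTT assay, with a stated time of 72 h; a higher number here means a weaker inhibitor, a lower number a stronger inhibitor
Compound 2, `N/C(=N\NC(=S)N1CCN(c2ccccn2)CC1)c1ccc(F)cn1`: 22000 nM in this assay
Compound 3, `Cc1cccc(/C(N)=N/NC(=S)N2CCSCC2)n1`: limit of > 100000 nM in this assay

Compound 3 reports only a limit, > 100000 nM, so its true value is not known. Compound 3 therefore sits at the limit of > 100000 nM in this assay, at which 1 of the 3 values shown sits, the weakest reading the assay can give. Compound 4, `N/C(=N\NC(=S)N1CCSCC1)c1ccccn1`, differs from compound 3 by hydrogen in place of methyl on an aromatic carbon. Among the measured compounds shown here, no two measured compounds differ in this one place alone, so the size of that step has not been seen directly. Compound 1 carries hydrogen at the same place and gives 2600 nM. For compound 4 a step toward stronger inhibition is expected, an at least 5.0-fold lower number from compound 3 to compound 4 (0.69 log units; beyond the scatter), though its ring differs from that of compound 1. Compound 4 is estimated at 20000 nM, within 3000 nM to 100000 nM.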

Compound 4, half-maximal inhibitory concentration: 8800 nM
Compound 4: middle estimate off by 2.3-fold (0.36 log units), on the high side; the measured number falls inside the stated range.
By their numbers in this assay, from the lowest: compound 1; then compound 4; then compound 2. At a limit, above all of these: compound 3.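

Taking the methyl off the aromatic carbon next to the ring nitrogen gives a directly observed step at this place in this assay: an at least 11-fold lower number from compound 3 to compound 4 (1.05 log units; beyond the scatter). The methyl alone thus separates a compound with a readable value from one without. The true size of the step stays unknown because compound 3 reports only a limit: the limit of > 100000 nM in this assay, at which 1 of the 4 values shown sits.

On these data alone, whether the methyl has the same effect on the core of compound 1 remains open. The compounds shown also leave open how an ethyl, a methoxy or a chlorine would read at this place.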